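Methyl on the phenyl of compound 1: an expected small step

A few compounds are considered here, and "the series" means these few. Any claim that something is new, unique, unknown or untested is made for them only; others in the source may bear on it.

For the measured compounds named here, compound 1 `CC1=NN(c2ccccc2)C(=O)[C@@]12C(=O)C=CC[C@H]2c1ccc(C)cc1` gives 5210 nM in a functional assay on HCT-116 cells (Homo sapiens) for inhibition, read by MTT assay, with a stated time of 72 h (a lower number here means a stronger inhibitor, a higher number a weaker inhibitor), and holds the lowest of the three numbers measured so far, with compound 2 nearest and compound 3 furthest, both within the scatter. Compound 2 `CC1=NN(c2ccccc2)C(=O)[C@@]12C(=O)C=CC[C@@H]2c1ccc(C)cc1` gives 5220 nM in this assay; the step of a 1.0-fold higher number from compound 1 to compound 2 (0.00 log units; within the scatter) goes with the fact that (the fact that compounds 1 and 2 differ only in the configuration as drawn). Compound 3 `CC1=NN(c2ccccc2)C(=O)[C@@]12C(=O)C=CC[C@H]2c1cccc(C)c1` gives 5820 nM in this assay, the step being a 1.1-fold higher number from compound 1 to compound 3 (0.05 log units; within the scatter), where a 3-methylphenyl stands in place of a 4-methylphenyl on a saturated ring carbon.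

Compound 4 `CC1=NN(c2ccc(C)cc2)C(=O)[C@@]12C(=O)C=CC[C@H]2c1ccc(C)cc1` is not yet measured. It differs from compound 1 as follows: methyl in place of hydrogen on an aromatic carbon. Neither measured step is of the same kind, since one changes configuration alone and the other moves a methyl on the phenyl at the saturated ring carbon; both stay within the scatter. Going by the values given here, the ring that gains the methyl here is not touched by either of them, so there is no measured step that bears on it directly. Given the two small steps seen, the expected step from compound 1 to compound 4 in this assay is none beyond the scatter: a 1.0-fold lower number from compound 1 to compound 4 (0.00 log units; within the scatter). Compound 4 is therefore estimated at 5200 nM, with a range from 2600 nM to 10400 nM.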

Compound 4, half-maximal inhibitory concentration: 3620 nM
For compound 4 the middle estimate is 1.4-fold (0.16 log units) above the measured one, and the stated range covers the measured number.
By their numbers in this assay, from the lowest: compounds 4, 1, 2 and 3 (each within the scatter of the next).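

Phenyl to 4-methylphenyl is the first reading at this ring, which neither earlier step touched, and in this assay the change stays within the scatter (a 1.4-fold lower number from compound 1 to compound 4 (0.16 log units; within the scatter)). For the compounds shown here, a methyl on an aromatic carbon, para to a large group, is therefore accommodated at this position without a step beyond the scatter, so the series so far shows no sensitivity to this small addition, just as it showed none to the two changes at the other end of the core. Nothing available explains why this ring accepts the methyl, and the single observation on configuration does not bear on this change.

On these data alone, one methyl at one place says little about how far this position tolerates change, so it remains open whether an amine, a carboxylic acid or a longer chain such as butyl in the same place would give a step beyond the scatter. As far as these compounds go, it is also open whether the methyl on this ring would read the same with the configuration of compound 2 or the 3-methylphenyl of compound 3.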